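Extending the Ether Chain One Stage Further

The source may report more compounds than this note shows. Statements on the series, on what has been measured and on what is new or still open speak of the compounds shown alone.

Compound 2 `CCCCOc1nc(C(C)(C)C)ccc1CNC(=O)C(C)c1ccc(NS(C)(=O)=O)c(F)c1` stands at the lower end of the two numbers available in an assay on cells for antagonist activity at transient receptor potential cation channel subfamily V member 1 (Homo sapiens), read by FLIPR and calcium flux, with a stated time of 6 min (a higher number here means a weaker inhibitor, a lower number a stronger inhibitor), where compound 2 gives 0.9 nM. Its nearest neighbour is compound 1 `CCOc1nc(C(C)(C)C)ccc1CNC(=O)C(C)c1ccc(NS(C)(=O)=O)c(F)c1`, which in this assay gives 14.8 nM. The step of a 16-fold lower number from compound 1 to compound 2 (1.22 log units; beyond the scatter) is the only one available, and it comes from a single change: ethyl in place of hydrogen on a saturated chain carbon, two bonds along the chain from an oxygen on an aromatic ring.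

Compound 3 `CCCCCCOc1nc(C(C)(C)C)ccc1CNC(=O)C(C)c1ccc(NS(C)(=O)=O)c(F)c1` carries the same kind of extension one stage further: ethyl in place of hydrogen on a saturated chain carbon, four bonds along the chain from an oxygen on an aromatic ring. Within the data shown here, only the step from compound 1 to compound 2 bears on this, and it was large. Whether a second extension of the same chain repeats that gain is not shown by the data, and with compound 2 already at the bottom of the range the room for another large drop may be limited. Compound 3 is therefore expected to sit near compound 2 or somewhat lower, an expected step of a 1.5-fold lower number from compound 2 to compound 3 (0.18 log units; within the scatter). The estimate for compound 3 in this assay is 0.6 nM, within a range from 0.2 nM to 2.5 nM.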

Compound 3, inhibition constant: 2.7 nM
Beside the measured number, compound 3's estimate is 4.5-fold (0.65 log units) below it; the measured number lies above the stated range.
By their numbers in this assay, from the lowest: compound 2; then compound 3; then compound 1.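

The same change of ethyl in place of hydrogen, moved to four bonds along the chain from an oxygen on an aromatic ring, turns the trend around in this assay, giving a 3.0-fold higher number from compound 2 to compound 3 (0.48 log units; beyond the scatter) where the earlier step had lowered the number. The lengthening therefore does not act steadily along this ether chain, and of the three compounds, compound 2 with its shorter chain is the strongest inhibitor, so the optimum among those shown lies at an intermediate chain rather than at the longest. Part of the earlier gain nevertheless survives the second extension, since butyl in place of hydrogen, two bonds along the chain from the oxygen, still gives a 5.5-fold lower number from compound 1 to compound 3 (0.74 log units; beyond the scatter) and leaves the longest chain ahead of the shortest, while no information is available on why the trend turns at this stage.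

Whether the true lowest point lies at compound 2 or at a propyl or pentyl chain on the same oxygen remains open, as the three chains shown sample this position only coarsely. Also open, going by these compounds, is how a branched chain such as isobutyl, or an amine or a carboxylic acid carried on the chain, would fare against compound 2 on the same core.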